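A few compounds are considered here, and "the series" means these few. Any claim that something is new, unique, unknown or untested is made for them only; others in the source may bear on it.

Measured compounds in an assay on RPMI-8866 cells for inhibition of integrin alpha-4/beta-1 (Homo sapiens); a higher number here means a weaker inhibitor, a lower number a stronger inhibitor:

Compound 1, `O=C(O)C[C@@H](NC(=O)[C@@H]1CCN1S(=O)(=O)c1cc(Cl)cc(Cl)c1)c1ccc(F)cc1`, gives 3.2 nM.
Compound 2, `O=C(O)C[C@@H](NC(=O)[C@@H]1CCN1S(=O)(=O)c1cc(Cl)cc(Cl)c1)c1ccc(OCF)cc1`, gives 0.72 nM.

Within the data shown here, compound 2 stands with the lowest number of the two; the only step to it, a 4.4-fold lower number from compound 1 to compound 2 (0.65 log units; beyond the scatter), is beyond the scatter and modest.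

Compound 3 is `O=C(O)C[C@@H](NC(=O)[C@@H]1CCN1S(=O)(=O)c1cc(Cl)cc(Cl)c1)c1ccc(OCC(F)(F)F)cc1`. Relative to compound 2 the change is trifluoromethyl in place of fluoro on a saturated chain carbon bound to an oxygen on an aromatic ring; read one bond further out, fluoromethoxy becomes 2,2,2-trifluoroethoxy.

Among the measured compounds shown here, the one measured step, a 4.4-fold lower number from compound 1 to compound 2 (0.65 log units; beyond the scatter), concerns a different exchange, fluoro on the aromatic carbon against fluoromethoxy, and so bears on compound 3 only loosely: it shows that this position tolerates a larger group without loss. Nothing measured speaks to further fluorination of the chain. The expectation for compound 3 is therefore a step of a 1.4-fold higher number from compound 2 to compound 3 (0.14 log units; within the scatter), that is, no clear change beyond the scatter, with a slight lean toward a higher number. Compound 3 is estimated at 1 nM in this assay, within a range from 0.4 nM to 3 nM.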

Compound 3, half-maximal inhibitory concentration: 1.4 nM
Beside the measured number, compound 3's estimate is 1.4-fold (0.15 log units) below it; measured number inside the range.
By their numbers in this assay, from the lowest: compounds 2 and 3 (each within the scatter of the next); then compound 1.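

In this assay, trifluoromethyl in place of fluoro on a saturated chain carbon bound to an oxygen on an aromatic ring gives a 1.9-fold higher number from compound 2 to compound 3 (0.29 log units; within the scatter), so fluoromethoxy and 2,2,2-trifluoroethoxy cannot be told apart at this position in this series. The exchange of fluoro on the aromatic carbon for a fluorinated ether now reads beyond the scatter with a second group, a 2.3-fold lower number from compound 1 to compound 3 (0.36 log units; beyond the scatter), and so no longer rests on fluoromethoxy alone. Nothing given here accounts for the number holding across the change from fluoromethoxy to 2,2,2-trifluoroethoxy.

On these data alone, both ethers carry fluorine, so it remains open how this assay reads for an unfluorinated ether such as methoxy or ethoxy, for a longer chain, or for an amine or a carboxylic acid at this position. As far as these compounds go, all three compounds also share one core, and whether the exchange of fluoromethoxy for 2,2,2-trifluoroethoxy reads the same on a different core remains open too.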